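Chlorine to Bromine on Two Related Cores

This account rests on a few compounds, and the source may have more. Where it says the series, first, only, none or still open, it means among the compounds named here.

Measured so far: compound 1 `Clc1ccccc1CSc1nnc(-c2cnccn2)o1` gives 12300 nM, compound 2 `Brc1ccccc1CSc1nnc(-c2cnccn2)o1` gives 4220 nM, and compound 3 `Clc1ccccc1CSc1nnc(-c2cnccn2)n1-c1ccccc1` gives 18800 nM, all in a functional assay on HepG2 cells (Homo sapiens) for antiproliferative activity, read by MTT assay, with a stated time of 48 h; on this read-out higher numbers stand for weaker inhibition and lower numbers for stronger inhibition.

Compounds 1 and 2 share a core and differ in one place: bromo in place of chloro on an aromatic carbon. That change gave a 2.9-fold lower number from compound 1 to compound 2 (0.46 log units; beyond the scatter). Compound 3 carries a different core; how the two cores differ is not broken down here. Compound 3 stands within the scatter of compound 1 and beyond it of compound 2.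

Compound 4 `Brc1ccccc1CSc1nnc(-c2cnccn2)n1-c1ccccc1` has not yet been measured. It differs from compound 3 in one place, (bromo in place of chloro on an aromatic carbon), the same change that turned compound 1 into compound 2. Resting on that single earlier step, the step from compound 3 to compound 4 is expected to run in the same direction, about a 2.2-fold lower number from compound 3 to compound 4 (0.34 log units; beyond the scatter), but since only one example of the change is available, a smaller step would not surprise. Compound 4 is therefore estimated at 8500 nM in this assay, expected between 3800 nM and 20000 nM.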

Compound 4, half-maximal inhibitory concentration: 11600 nM
Compound 4: middle estimate off by 1.4-fold (0.14 log units), on the low side; low and high end bracket the measured number.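

In this assay, the same exchange of chloro for bromo on the second core gave a 1.6-fold lower number from compound 3 to compound 4 (0.21 log units; within the scatter), a step that cannot be told apart from the scatter of repeated measurements. Set beside the step on the first core, it shows no measurable dependence on the core: the same change on two cores in this assay, a 2.9-fold lower number (0.46 log units; beyond the scatter) from compound 1 to compound 2 and a 1.6-fold lower number (0.21 log units; within the scatter) from compound 3 to compound 4, 1.8-fold (0.25 log units) apart, within the scatter of two such steps. Among these compounds, the two results are therefore compatible with the change carrying over from one core to the other at a similar size, but they do not establish this, since only one of the two steps stands clear of the scatter, only two cores are represented, and a modest real difference between the cores would go unseen.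

The compounds shown leave open whether the trend extends beyond these two halogens, for instance to an iodo, fluoro or methoxy group on the same aromatic carbon. They also leave open whether the exchange behaves alike on cores bearing other substituents, such as an amine or a longer alkyl chain.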